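The compounds below may be only part of what the source reports. "The series", "measured", "known", "first", "only" and "open" are said of these compounds alone.

Compound 1 `COc1cc(-c2nccn2S(=O)(=O)c2ccccc2)cc(OC)c1OC`: > 100000 nM
Compound 2 `COc1ccc(NC(=O)c2cc(OC)c(OC)c(OC)c2)cc1[N+](=O)[O-]`: 31000 nM

Both compounds were tested in a functional assay on MDA-MB-231 cells (Homo sapiens) for antiproliferative activity, read by MTT assay, with a stated time of 72 h; on this read-out higher numbers stand for weaker inhibition and lower numbers for stronger inhibition. The entry for compound 1, > 100000 nM, is a limit of the assay and not a number. Going by the values given here, that leaves compound 2 as the only compound with a true number so far, at 31000 nM in this assay.

Compound 3 `COc1ccc(NC(=O)c2cc(OC)c(OC)c(OC)c2)cc1N` differs from compound 2 in one place: amino in place of nitro on an aromatic carbon, ortho to a methoxy group (amino in place of nitro on an aromatic carbon). Among the compounds with values here, no measured pair of compounds shows what this swap does, so any forecast is uncertain. A modest gain in this assay seems the likeliest outcome, towards stronger inhibition, starting from compound 2 at 31000 nM. The expected change is a 2.6-fold lower number from compound 2 to compound 3 (0.41 log units; beyond the scatter). For compound 3 the estimated value is 12000 nM, with an expected range from 2500 nM to 50000 nM.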

Compound 3, half-maximal inhibitory concentration: 18600 nM
Estimate against measurement, compound 3: 1.6-fold (0.19 log units) below; measured number inside the range.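

In this assay, going by these compounds alone, the swap of nitro for amino is the first step that can be read, and it gives a 1.7-fold lower number from compound 2 to compound 3 (0.22 log units; within the scatter) at this place on the aromatic ring. This place, ortho to a methoxy group, therefore carries either a group of 3 heavy atoms with no hydrogen-bond donor or a group of 1 heavy atom with 1 hydrogen-bond donor, and the two compounds cannot be told apart on this read-out. Nothing shown gives a cause for this result.

From the compounds shown here alone, whether a hydroxyl group, a methyl group or an acetamide at the same place would stand apart from compound 2 and compound 3 remains open. Going by these compounds, it is also open whether swapping the neighbouring methoxy group for an ethoxy group would change the picture.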